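The compounds below may be only part of what the source reports. "The series", "measured", "known", "first", "only" and "open" are said of these compounds alone.

Measured so far:
compound 1 `CS/C(=N\C(=O)c1csc([N+](=O)[O-])c1)NC(=O)c1csc([N+](=O)[O-])c1`, 44700 nM
compound 2 `O=C(/N=C(/NC(=O)c1ccco1)[Se]Cc1ccccc1)c1ccco1`, 8800 nM

For the measured compounds named here, in a functional assay on MCF7 cells (Homo sapiens) for cytotoxicity, read by MTT assay, with a stated time of 72 h (on this read-out lower numbers stand for stronger inhibition of growth and higher numbers for weaker inhibition of growth), compound 1 stands at the higher of the two numbers; compound 2 sits lower, beyond the scatter, but the two differ in more than one place, so no single step is read from them. Compound 3 `O=C(/N=C(/NC(=O)c1csc([N+](=O)[O-])c1)[Se]Cc1ccccc1)c1csc([N+](=O)[O-])c1` differs from compound 1 by a group of 8 heavy atoms (7 carbon, 1 selenium; one six-membered aromatic ring of carbon only) in place of a group of 2 heavy atoms (1 carbon, 1 sulfur; no ring), on a carbon with a double bond to nitrogen. Going by the values given here, with no matched step available, a move toward a lower number is expected, of moderate size; the expected step is a 3.0-fold lower number from compound 1 to compound 3 (0.47 log units; beyond the scatter). Compound 3 is expected to give 15000 nM, within 5000 nM to 45000 nM.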

Compound 3, concentration for 50% growth inhibition: 24400 nM
Estimate against measurement, compound 3: 1.6-fold (0.21 log units) below; measured number inside the range.
By their numbers in this assay, from the lowest: compound 2; then compounds 3 and 1 (each within the scatter of the next).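

In this assay, for the compounds shown here, placing the group of 8 heavy atoms, with its selenium and six-membered aromatic ring, in place of methylsulfanyl on a carbon with a double bond to nitrogen gives a 1.8-fold lower number from compound 1 to compound 3 (0.26 log units; within the scatter) and so provides the first matched reading at this position. Despite the larger group entering, this single change does not separate the two compounds beyond the scatter. No measured evidence bears on this step. 

Open, on these data alone, is whether an amine or a longer chain on this carbon would give a step beyond the scatter. Also open, as far as these compounds go, is whether exchanging selenium for sulfur, with the benzene ring kept, would change the number.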